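Capping the ring nitrogen of the shared core

The source may hold more compounds than are shown below. What is called first, only, known or untested is meant among the compounds shown, and "the series" means these compounds.

Measured so far:
- compound 1 `O=C(Nc1ccc(Oc2ccnc3[nH]ccc23)c(F)c1)c1cc2cccnc2n(-c2ccc(F)cc2)c1=O`: 62 nM
- compound 2 `O=C(Nc1ccc(Oc2ccnc3[nH]ccc23)c(F)c1)c1cc2cccnc2n(-c2ccc(F)c(Cl)c2)c1=O`: 630 nM

In a functional assay on A549 cells (Homo sapiens) for antiproliferative activity, read by MTT assay, with a stated time of 72 h (on this read-out higher numbers stand for weaker inhibition and lower numbers for stronger inhibition), compound 1 gives 62 nM, the lowest of the two numbers; compound 2 gives 630 nM. Going by the values given here, the one measured step, a 10-fold higher number from compound 1 to compound 2 (1.01 log units; beyond the scatter), concerns a change on the aryl ring attached to the pyridone nitrogen and leaves the fused bicyclic part of the core untouched.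

Compound 3 `Cn1ccc2c(Oc3ccc(NC(=O)c4cc5cccnc5n(-c5ccc(F)cc5)c4=O)cc3F)ccnc21` differs from compound 1 by methyl in place of hydrogen on an aromatic nitrogen. Among the compounds with values here, no measured step bears on this position, so the change is unanchored by the data; the only precedent, a 10-fold higher number from compound 1 to compound 2 (1.01 log units; beyond the scatter), shows that a single small substituent elsewhere on compound 1 moved the number well beyond the scatter. The expectation is therefore a step in this assay toward a higher number, but of uncertain size, with a wide range.

For compound 3 the estimated value is 250 nM, between 50 nM and 2000 nM, corresponding to an expected step of a 4.0-fold higher number from compound 1 to compound 3 (0.61 log units; beyond the scatter).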

Compound 3, half-maximal inhibitory concentration: 280 nM
Compound 3: middle estimate off by 1.1-fold (0.05 log units), on the low side, and the stated range covers the measured number.
By their numbers in this assay, from the lowest: compound 1; then compound 3; then compound 2.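

In this assay, going by these compounds alone, methyl in place of hydrogen on an aromatic nitrogen gives a 4.5-fold higher number from compound 1 to compound 3 (0.65 log units; beyond the scatter) and so supplies the first measured step on the fused part of the shared core. The change to this nitrogen shifts the number beyond the scatter without removing activity, as compound 3 still gives 280 nM in this assay. No measurement available here explains this step.

Whether the step comes from losing the hydrogen on that nitrogen or from adding the methyl remains unresolved, and an ethyl group, a longer chain ending in an amine, or a chain ending in a carboxylic acid on the same nitrogen could help separate the two. Also open, as far as these compounds go, is whether the same nitrogen change would give a similar step with the chloro substituent of compound 2 in place.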